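This account rests on a few compounds, and the source may have more. Where it says the series, first, only, none or still open, it means among the compounds named here.

Within the data shown here, compound 2 `CCCCCCCCCCCCCCCCCCOCC1CC(COC(=O)CCCCC[n+]2ccsc2)CO1` holds the lowest of the two numbers so far in a functional assay (Oryctolagus cuniculus) for inhibition of platelet-activating factor receptor (Cavia porcellus) (on this read-out higher numbers stand for weaker inhibition and lower numbers for stronger inhibition), giving 1500 nM. Among the measured compounds shown here, its only neighbour, compound 1 `CCCCCCCCCCCCCCCCCCOCC1CC(COCCCCCCC[n+]2ccsc2)CO1`, gives 3900 nM in this assay, and the one measured step, a 2.6-fold lower number from compound 1 to compound 2 (0.41 log units; beyond the scatter), is modest but beyond the scatter. Compound 3 `CCCCCCCCCCCCCCCCCCOCC1CC(COCCCCC[n+]2ccsc2)CO1` is the next member and has no number yet. Relative to compound 2 the change is a group of 10 heavy atoms (8 carbon, 1 nitrogen, 1 sulfur; one five-membered aromatic ring with 2 hetero atoms) in place of a group of 12 heavy atoms (9 carbon, 1 nitrogen, 1 oxygen, 1 sulfur; one five-membered aromatic ring with 2 hetero atoms), on an oxygen on a saturated carbon: the leaving group carries the one double bond outside aromatic rings and the second hydrogen-bond acceptor, the entering group has neither, and both groups sit on the same oxygen on a saturated carbon. The step from compound 1 to compound 2 is the only one that bears on this, and it runs the opposite way: it brought the double bond and the extra acceptor in and the number fell. Undoing that in compound 3 is therefore expected to move the number back up, roughly by the size seen, so a step of a 2.2-fold higher number from compound 2 to compound 3 (0.34 log units; beyond the scatter) is estimated. Compound 3 is accordingly expected near 3300 nM, within 1400 nM to 8000 nM.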

Compound 3, half-maximal inhibitory concentration: 2100 nM
Compound 3: middle estimate off by 1.6-fold (0.20 log units), on the high side; the range from low to high includes it.
By their numbers in this assay, from the lowest: compounds 2, 3 and 1 (each within the scatter of the next, the first and the last beyond it).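

In this assay the group of 10 heavy atoms on the oxygen on a saturated carbon, which has no double bond outside the ring and only one hydrogen-bond acceptor, cannot be told apart from the group of 12 heavy atoms that has both, since a 1.4-fold higher number from compound 2 to compound 3 (0.15 log units; within the scatter) is printed as within the scatter. The change on the saturated chain carbon also gives no separable difference, with a 1.9-fold lower number from compound 1 to compound 3 (0.27 log units; within the scatter) lying within the scatter as well, so compound 3 sits within the scatter of both neighbours and only the gap of a 2.6-fold lower number from compound 1 to compound 2 (0.41 log units; beyond the scatter) remains beyond it, which means that this gap can no longer be tied firmly to the carbonyl alone. No measurement is available that accounts for any of these numbers.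

Still open, from the compounds shown here alone, is whether a carbonyl placed on the group of 10 heavy atoms would separate from compound 3, and how an amide or a carbamate at the same oxygen would read. Among these compounds, also open are a chain longer than the one in compound 1 and a pyridinium ring in place of the five-membered aromatic ring with 2 hetero atoms.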